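Side-chain shortening from compound 3 to compound 4

A few compounds are considered here, and "the series" means these few. Any claim that something is new, unique, unknown or untested is made for them only; others in the source may bear on it.

In an ADME assay on a cell-free system (plasma, Rattus norvegicus) for metabolic stability, read by LC-MS, with a stated time of 120 min, tested at 200 uM (a higher number here means that the compound lasts longer, a lower number that the compound disappears faster), compound 3 (`N[C@@H](CCC(=O)O[C@H]1C[C@H](n2cc(F)c(=O)[nH]c2=O)O[C@@H]1CO)C(=O)O`) gives 1.62 h and lies within the scatter of the two other measured compounds. These are compound 1 (`N[C@@H](CCC(=O)OC[C@H]1O[C@@H](n2cc(F)c(=O)[nH]c2=O)C[C@@H]1OC(=O)CC[C@H](N)C(=O)O)C(=O)O`) at 1.13 h and compound 2 (`N[C@@H](CC(=O)OC[C@H]1O[C@@H](n2cc(F)c(=O)[nH]c2=O)C[C@@H]1OC(=O)C[C@H](N)C(=O)O)C(=O)O`) at 0.935 h in the same test.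

Compound 4 (`N[C@@H](CC(=O)O[C@H]1C[C@H](n2cc(F)c(=O)[nH]c2=O)O[C@@H]1CO)C(=O)O`) has not yet been measured. Its difference from compound 3 (amino(carboxy)methyl in place of 2-amino-2-carboxyethyl on a saturated chain carbon bound to a carbonyl carbon) is amino(carboxy)methyl in place of 2-amino-2-carboxyethyl on a saturated chain carbon bound to a carbonyl carbon.

For the measured compounds named here, no measured step isolates this change. The nearest single-place step is a 1.4-fold higher number from compound 1 to compound 3 (0.16 log units; within the scatter) and lies within the scatter, but it removes a whole (3-amino-3-carboxypropyl)carbonyl group and does not shorten a chain. The same swap of chains occurs twice between compound 1 and compound 2, which also differ in two places, and their two values lie within the scatter of each other.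

No step beyond the scatter is therefore expected in this assay for a single swap, and any shift is expected to be small and downward. The estimated 1.2-fold lower number from compound 3 to compound 4 (0.06 log units; within the scatter) stays within the scatter. Compound 4 is estimated at 1.4 h in this test, with a range from 0.8 h to 2.4 h expected for repeat measurements.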

Compound 4, half-life: 2.06 h
The estimate for compound 4 lay 1.5-fold (0.17 log units) below the measured number; the range from low to high includes it.
By their numbers in this assay, from the lowest: compounds 2, 1, 3 and 4 (each within the scatter of the next, the first and the last beyond it).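

In this assay, amino(carboxy)methyl and 2-amino-2-carboxyethyl on a saturated chain carbon bound to a carbonyl carbon can now be compared directly, and a 1.3-fold higher number from compound 3 to compound 4 (0.10 log units; within the scatter) shows that this single swap cannot be told apart from the scatter. For the compounds shown here, replacing the whole acyl group with hydrogen, on an oxygen on a saturated carbon, gives the first single-place step beyond the scatter, though a modest one: a 2.2-fold higher number from compound 2 to compound 4 (0.34 log units; beyond the scatter). Going by these compounds alone, the corresponding replacement with the longer chain, a 1.4-fold higher number from compound 1 to compound 3 (0.16 log units; within the scatter), stays within the scatter, so a step beyond the scatter for this kind of replacement is seen only with the shorter chain.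

No data shown here account for either step. Still open, on these data alone, is whether a longer chain at this place, or a chain that carries only an amine or only a carboxylic acid, would also keep the half-life within the scatter of compound 3 and compound 4.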